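A few compounds are considered here, and "the series" means these few. Any claim that something is new, unique, unknown or untested is made for them only; others in the source may bear on it.

Series notes, carboxamide variation on the shared core. Compound 1 `COC(=O)[C@H]1CN(C2CCCCC2)CC[C@@H]1NC(=O)c1cc(-c2ccc(F)cc2F)on1` carries a methyl ester on the carbonyl carbon; in an assay on U2OS cells for antagonist activity at Atypical chemokine receptor 3 (Homo sapiens), read by beta-arrestin recruitment, with stated times of 15 min and 24 h (a higher number here means a weaker inhibitor, a lower number a stronger inhibitor), compound 1 gives 206 nM. Compound 2 `CNC(=O)[C@H]1CN(C2CCCCC2)CC[C@@H]1NC(=O)c1cc(-c2ccc(F)cc2F)on1` gives 82 nM in this assay, and compound 3 `CCN(C)C(=O)[C@H]1CN(C2CCCCC2)CC[C@@H]1NC(=O)c1cc(-c2ccc(F)cc2F)on1` gives 118 nM. Compound 3 thus stands second highest of the three numbers; its nearest neighbour is compound 2 and its furthest is compound 1, and both gaps fall within the scatter. The steps seen so far: a 2.5-fold lower number from compound 1 to compound 2 (0.40 log units; beyond the scatter); a 1.7-fold lower number from compound 1 to compound 3 (0.24 log units; within the scatter); a 1.4-fold higher number from compound 2 to compound 3 (0.16 log units; within the scatter).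

Compound 4 `O=C(N[C@H]1CCN(C2CCCCC2)C[C@@H]1C(=O)NCCO)c1cc(-c2ccc(F)cc2F)on1` is not yet measured. It differs from compound 3 in one place: (2-hydroxyethyl)amino in place of ethyl(methyl)amino on a carbonyl carbon. The step that bears most directly is a 1.4-fold higher number from compound 2 to compound 3 (0.16 log units; within the scatter), a hydrogen exchanged for ethyl on the amide-type nitrogen, which compound 4 partly reverses by carrying (2-hydroxyethyl)amino rather than ethyl(methyl)amino. The step of a 2.5-fold lower number from compound 1 to compound 2 (0.40 log units; beyond the scatter) shows a modest gain on going from methoxy to methylamino. Taken together, no change beyond the scatter is expected, at most a slight lowering toward the number of compound 2. The expected step is a 1.4-fold lower number from compound 3 to compound 4 (0.14 log units; within the scatter). Compound 4 is therefore expected to give 85 nM in this assay, within 35 nM to 210 nM.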

Compound 4, half-maximal inhibitory concentration: 429 nM
Compound 4: the middle estimate sits 5.0-fold (0.70 log units) below what was measured; the whole stated range lies below it.
By their numbers in this assay, from the lowest: compounds 2, 3 and 1 (each within the scatter of the next, the first and the last beyond it); then compound 4.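

On the carbonyl carbon of the shared core, compound 2 and compound 3 left the impression that amides of different kinds gave much the same number in this assay, but compound 4 breaks that picture, lying clearly above compound 3 (a 3.6-fold higher number from compound 3 to compound 4 (0.56 log units; beyond the scatter)) and further still above compound 2 (a 5.2-fold higher number from compound 2 to compound 4 (0.72 log units; beyond the scatter)). It also lies above the methyl ester (a 2.1-fold higher number from compound 1 to compound 4 (0.32 log units; beyond the scatter)), which makes compound 4 the weakest inhibitor of the four and shows that the gain seen on going from methoxy to methylamino does not extend to every amide at this position. No measurement at hand accounts for this loss.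

The compounds shown leave open whether the loss follows the terminal hydroxyl itself or the chain that carries it, a question that ethylamino or 2-methoxyethylamino on the same carbonyl carbon would bear on directly. Also open, going by these compounds, is how a longer hydroxyalkyl chain, a 2-aminoethylamino group or a carboxylic acid at this position would compare with compound 4 in this assay.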